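This account rests on a few compounds, and the source may have more. Where it says the series, first, only, none or still open, it means among the compounds named here.

Compound 1 `COc1cccc(Nc2nc(C)cc(N(C)C)n2)c1` and compound 2 `COc1cc(Nc2nc(C)cc(N3CCCC3)n2)ccc1F` share a common core. In a physicochemical assay for solubility, read by nephelometry, measured as kinetic solubility (on this read-out lower numbers stand for lower solubility and higher numbers for higher solubility), compound 1 gives > 250000 nM, which is a limit of the assay and not a number (the limit of > 250000 nM in this assay, at which 1 of the 2 values shown sits). In this assay, for the measured compounds named here, compound 2 gives 220000 nM, the only number among the values so far. Compound 3 `COc1cc(Nc2nc(C)cc(NCc3ccccc3)n2)ccc1F` differs from compound 2 by benzylamino in place of pyrrolidin-1-yl on an aromatic carbon. Going by the values given here, no step between measured compounds is available; the step from compound 2 to compound 3 is expected to move toward lower solubility, beyond the usual scatter, as a 2.4-fold lower number from compound 2 to compound 3 (0.39 log units; beyond the scatter). Compound 3 is therefore estimated at 90000 nM, within 30000 nM to 250000 nM.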

Compound 3, solubility: > 250000 nM
Compound 3 gave a limit, no number; the forecaster's own chance of this, stated with the estimate: 15%; middle value at least 2.7-fold (0.44 log units) from the limit.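

In this assay, benzylamino in place of pyrrolidin-1-yl on this aromatic carbon, next to the ring nitrogen, gives an at least 1.1-fold higher number from compound 2 to compound 3 (0.05 log units; that floor lies within the scatter). Adding the six-membered aromatic ring of carbon only and a hydrogen-bond donor at this position therefore does not bring the number down, though no rise can be claimed either. The size of the step stays unread, since the value of compound 3 is a limit of the assay and not a number: the limit of > 250000 nM in this assay, at which 2 of the 3 values shown sit.

Going by these compounds, whether morpholine or phenethylamino at this carbon would give a number inside the range of this assay stays open.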